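Thiophene in place of dimethoxyphenyl on a shared core

A few compounds are considered here, and "the series" means these few. Any claim that something is new, unique, unknown or untested is made for them only; others in the source may bear on it.

Measured compounds:
Compound 1, `CCOC(=O)c1cnn(-c2nc(-c3cccc(OC)c3OC)c(C#N)c(=O)n2C)c1N`, gives 67 ug/mL in a functional assay, with a stated time of 10 min; a higher number here means a weaker inhibitor, a lower number a stronger inhibitor.
Compound 2, `COc1cccc(-c2nc(NN)n(C)c(=O)c2C#N)c1OC`, gives 36 ug/mL in this assay.

Compound 1 holds the higher of the two numbers in this assay, but its gap to compound 2 lies within the scatter, so neither compound can be called the stronger inhibitor on these data. Compound 3, `CCOC(=O)c1cnn(-c2nc(-c3cccs3)c(C#N)c(=O)n2C)c1N`, has not yet been measured. It differs from compound 1 in one place: thiophen-2-yl in place of 2,3-dimethoxyphenyl on an aromatic carbon. Among the measured compounds shown here, no pair among the measured compounds shows this kind of change, so nothing here tells how large a step it brings. For the measured compounds named here, with no such step available, the expectation for this assay is a change of no more than the scatter, in either direction. On that basis compound 3 is estimated at 60 ug/mL, with a range from 25 ug/mL to 150 ug/mL. The step this estimate implies is expected to be a 1.1-fold lower number from compound 1 to compound 3 (0.05 log units; within the scatter).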

Compound 3, half-maximal inhibitory concentration: 109 ug/mL
Compound 3: middle estimate off by 1.8-fold (0.26 log units), on the low side; the range from low to high includes it.
By their numbers in this assay, from the lowest: compounds 2, 1 and 3 (each within the scatter of the next, the first and the last beyond it).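

In this assay, thiophen-2-yl in place of 2,3-dimethoxyphenyl gives a 1.6-fold higher number from compound 1 to compound 3 (0.21 log units; within the scatter), so neither compound 1 nor compound 3 can be called the stronger inhibitor. At this position, on an aromatic carbon ortho to a cyano group, a group of 5 heavy atoms with one five-membered aromatic ring therefore stands in for one of 10 heavy atoms with a six-membered ring, without a step that can be told from the scatter. Nothing available explains the size of this step.

The compounds shown leave open whether an unsubstituted phenyl, a single methoxyphenyl or a furan-2-yl group at this position would also stay within the scatter of compound 1. They also leave open whether thiophen-2-yl would give a similar step on the core of compound 2.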